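Compound 3: Side-Chain Swap on the Shared Core

The source may hold more compounds than are shown below. What is called first, only, known or untested is meant among the compounds shown, and "the series" means these compounds.

In an ADME assay on NCM460 cells (Homo sapiens) for cytotoxicity, read by CCK-8 assay, with a stated time of 48 h (on this read-out lower numbers stand for stronger inhibition and higher numbers for weaker inhibition), compound 1 `COc1ccc(/C=C\c2cc(OC)c(OC)c(OC)c2)cc1OCc1ccc(CNCCO)cc1` gives 39000 nM and compound 2 `COc1ccc(/C=C\c2cc(OC)c(OC)c(OC)c2)cc1OCc1ccc(CN2CC[C@H](O)C2)cc1` gives 51000 nM, so compound 2 stands level with compound 1 within the scatter. Compound 3 `COc1ccc(/C=C\c2cc(OC)c(OC)c(OC)c2)cc1OCc1ccc(CN[C@H](C(=O)O)[C@@H](C)O)cc1` differs from compound 2 by (1-carboxy-2-hydroxypropyl)amino in place of 3-hydroxypyrrolidin-1-yl on a saturated chain carbon bound to an aromatic carbon: (1-carboxy-2-hydroxypropyl)amino in place of 3-hydroxypyrrolidin-1-yl. For the measured compounds named here, the only measured step at this place is a 1.3-fold higher number from compound 1 to compound 2 (0.12 log units; within the scatter). Going by the values given here, no measured compound carries a carboxy group, so this guide is weak. On that single step, the expected change is a 1.2-fold higher number from compound 2 to compound 3 (0.07 log units; within the scatter), with none expected beyond the scatter. For compound 3 the estimate is 60000 nM, with an expected range of 22000 nM to 160000 nM.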

Compound 3, half-maximal inhibitory concentration: > 50000 nM
Compound 3: a limit, no number (the forecaster's own chance of this, stated with the estimate: 25%); the middle value does not contradict the limit.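

In this assay, compound 3 reads only as a limit and not as a number: the limit of > 50000 nM in this assay, at which 1 of the 3 values shown sits. Replacing 2-hydroxyethyl with 1-carboxy-2-hydroxypropyl on the amine nitrogen gives an at least 1.2-fold higher number from compound 1 to compound 3 (0.10 log units; that floor lies within the scatter), while the step from compound 2 to compound 3 cannot be read. From the compounds shown here alone, a carboxy-bearing group on this saturated chain carbon bound to an aromatic carbon therefore leaves the read-out at the limit, and the size of any change stays unknown.

Going by these compounds, it remains open whether a methyl ester in place of the carboxylic acid, or a plain dimethylamino group at this place, would give a readable number in this assay.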